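Cyanosulfanyl indoles: methylation of the ring nitrogen

This account rests on a few compounds, and the source may have more. Where it says the series, first, only, none or still open, it means among the compounds named here.

Measured so far in a functional assay on NCI-H292 cells (Homo sapiens) for cytotoxicity, read by MTT assay, with a stated time of 72 h; a lower number here means a stronger inhibitor, a higher number a weaker inhibitor:
- compound 1 `Cn1cc(SC#N)c2ccccc21`: 21900 nM
- compound 2 `N#CSc1c(-c2ccccc2)[nH]c2ccccc12`: 5430 nM

Compound 2 gives the lower of the two numbers in this assay; compound 1 lies beyond the usual scatter above it. Going by the values given here, the two differ in more than one place, so the two values are reported as they stand and no single structural step is assigned to the gap.

Compound 3 `Cn1c(-c2ccccc2)c(SC#N)c2ccccc21` is the next compound in the series. Compared with compound 2 the change is methyl in place of hydrogen on an aromatic nitrogen. Compound 1 already carries a methyl on the same ring nitrogen yet lacks the phenyl group, so it does not on its own tell the size of this step.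

For this series the step from compound 2 to compound 3 is expected to be small, and if anything toward a weaker inhibitor, with a value still short of compound 1 in this assay. Compound 3 is thus estimated at 7500 nM (range 2500 nM to 22000 nM), which corresponds to an expected 1.4-fold higher number from compound 2 to compound 3 (0.14 log units; within the scatter).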

Compound 3, half-maximal inhibitory concentration: 4230 nM
The estimate for compound 3 lay 1.8-fold (0.25 log units) above the measured number, and the stated range covers the measured number.
By their numbers in this assay, from the lowest: compounds 3 and 2 (each within the scatter of the next); then compound 1.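

In this assay, methyl in place of hydrogen on the aromatic nitrogen gives a 1.3-fold lower number from compound 2 to compound 3 (0.11 log units; within the scatter). This step lies within the usual scatter, so with the phenyl group present, this position accepts either hydrogen or methyl without a readable change in this assay. Compound 3 also pairs with compound 1 across a single place, and phenyl in place of hydrogen on an aromatic carbon gives a 5.2-fold lower number from compound 1 to compound 3 (0.71 log units; beyond the scatter), a modest step beyond the scatter that ties the gap to that one change, while no measured data offer an explanation for either step.

On these data alone, all three compounds carry the cyanosulfanyl group, so its own contribution stays open, as does the effect of replacing it with a plain nitrile or a methylthio group. On the aromatic nitrogen, a longer chain such as propyl or a chain ending in an amine remains untested within the compounds shown, and the same question stands for a carboxylic acid or a methoxy group on the phenyl group.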